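This account rests on a few compounds, and the source may have more. Where it says the series, first, only, none or still open, it means among the compounds named here.

Measured compounds, with their values in a physicochemical assay for acid dissociation, using potentiometric titration:

Compound 1 `O=c1ccn(CCN2CCCCC2)c(CO)c1O`: 7.35
Compound 2 `Cc1c(O)c(=O)ccn1CCN(C)C`: 7.05
Compound 3 `CC(O)c1c(O)c(=O)ccn1CCN1CCCCC1`: 7.37

Compound 1 and compound 3 share a core; they differ by methyl in place of hydrogen on a saturated chain carbon bound to an aromatic carbon and an oxygen on a saturated carbon. In this assay that change made a number 0.02 log units higher from compound 1 to compound 3 (within the scatter), so the two numbers are indistinguishable. Compound 2 carries a different core; the difference between the two cores is not broken down here. Its value in this assay sits within the scatter of compound 1, while compound 3 is higher than compound 2 by a gap that lies beyond the scatter.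

Compound 4 `CCc1c(O)c(=O)ccn1CCN(C)C` has not yet been measured in this assay. It differs from compound 2 by methyl in place of hydrogen on a saturated chain carbon bound to an aromatic carbon. This is the same kind of change as that from compound 1 to compound 3, though not the same: around the place of the earlier change the saturated chain carbon is also bound to an oxygen on a saturated carbon, which is absent here. Going by the values given here, the only measured step of this kind, a number 0.02 log units higher from compound 1 to compound 3 (within the scatter), did nothing beyond the scatter. On that basis the step from compound 2 to compound 4 in this assay is expected to be small as well, a number 0.05 log units higher from compound 2 to compound 4 (within the scatter). Compound 4 is therefore estimated at 7.1, with a plausible range from 6.8 to 7.4, the width reflecting that the surroundings of the change differ from the measured case.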

Compound 4, acid dissociation constant: 6.88
Compound 4: middle estimate off by 0.22 log units, on the high side; measured number inside the range.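

In this assay the new step reads a number 0.17 log units lower from compound 2 to compound 4 (within the scatter), and the earlier step of the same kind reads a number 0.02 log units higher from compound 1 to compound 3 (within the scatter). Methyl in place of hydrogen therefore gives no step beyond the scatter in either core, whether or not the saturated chain carbon is also bound to an oxygen on a saturated carbon, and the opposite directions printed for the two steps do not establish a real difference between the cores. This is a finding from two matched pairs only: it does not show that the change would stay this small in other cores of the series, and no independent measurement is available to explain either step.

The compounds shown leave open whether a longer chain, such as propyl, or a larger change, such as an amine or a carboxylic acid, on the same saturated chain carbon would also stay within the scatter of compound 2 in this assay. They also leave open whether the same methyl change gives a similarly small step when the dimethylamino or piperidine group on the side chain is replaced by a morpholine.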